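The source may hold more compounds than are shown below. What is called first, only, known or untested is meant among the compounds shown, and "the series" means these compounds.

In a functional assay on HeLa cells (Homo sapiens) for antiproliferative activity, read by cell counting, with a stated time of 4 days (a higher number here means a weaker inhibitor, a lower number a stronger inhibitor), compound 1 (`CCOC(=O)C(=O)N(Cc1ccccc1)c1ccc2c(c1)OC(C)(CO)CN2C`) reads > 100000 nM, which is a limit of the assay. Compound 2 (`CN1CC(C)(CO)Oc2cc(N(Cc3ccccc3)C(=O)C(=O)O)ccc21`) reads > 100000 nM, also a limit. Within the data shown here, compound 3 (`CCOC(=O)C(=O)N(Cc1cc(F)cc(F)c1)c1ccc2c(c1)OC(C)(CO)CN2C`) gives 44000 nM, the only actual number in the set, reached through an at least 2.2-fold lower number from compound 1 to compound 3 (0.35 log units; beyond the scatter). Compound 4 (`CN1CC(C)(CO)Oc2cc(N(Cc3cc(F)cc(F)c3)C(=O)C(=O)O)ccc21`) departs from compound 3 by hydrogen in place of ethyl on an oxygen next to a carbonyl group, which turns ethoxycarbonyl to carboxy. The same exchange appears in a step that the two limits leave unreadable from compound 1 to compound 2, so this precedent gives direction only weakly and no size. For compound 4 the expected step is a 2.3-fold higher number from compound 3 to compound 4 (0.36 log units; beyond the scatter), a tentative move toward weaker inhibition in this assay, with no gain seen in that precedent. Compound 4 is estimated at 100000 nM, with an expected range of 45000 nM to 220000 nM.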

Compound 4, half-maximal inhibitory concentration: > 100000 nM
Compound 4: no number, only a limit; the forecaster's own chance of this, stated with the estimate: 60%; the middle value lies on the limit itself.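

In this assay, the change from ethoxycarbonyl to carboxy can now be read, as an at least 2.2-fold higher number from compound 3 to compound 4 (0.35 log units; beyond the scatter), whereas the same change on the phenyl compounds gave no readable step. As far as these compounds go, compound 4 reads > 100000 nM, which is a limit of the assay, so the full size of this step stays unknown. The steps from compound 1 to compound 2 and from compound 2 to compound 4 cannot be read, as both ends of each are limits: the limit of > 100000 nM in this assay, at which 3 of the 4 values shown sit.

From the compounds shown here alone, it remains open how a carboxamide or a propoxycarbonyl group would read in place of ethoxycarbonyl on the 3,5-difluorophenyl compound.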